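Working notes: two measured amides and one awaiting measurement

The source may report more compounds than this note shows. Statements on the series, on what has been measured and on what is new or still open speak of the compounds shown alone.

compound 1 `O=C(Nc1ccc(Cl)cc1)c1ccnc2cc(Br)ccc12` — a functional assay on KYSE-410 cells (Homo sapiens) for antiproliferative activity, read by MTT assay, with a stated time of 72 h; a higher number here means a weaker inhibitor, a lower number a stronger inhibitor: > 20000 nM, a limit of the assay rather than a number
compound 2 `COc1ccc(-c2ccc3c(C(=O)Nc4cccc(F)c4)cc(=O)[nH]c3c2)cc1` — this assay: 18000 nM

Among the measured compounds shown here, compound 2 holds the only number in the set; the other entry, that of compound 1, is a limit of the assay (the limit of > 20000 nM in this assay, at which 1 of the 2 values shown sits). Compound 3 `O=C(Nc1cccc(F)c1)c1cc(=O)[nH]c2cc(-c3ccc(F)c(CO)c3)ccc12` differs from compound 2 in one place: 4-fluoro-3-(hydroxymethyl)phenyl in place of 4-methoxyphenyl on an aromatic carbon. For the measured compounds named here, no step between measured compounds exists, so the effect of this change has no calibration from the set. The step of a 1.2-fold lower number from compound 2 to compound 3 (0.08 log units; within the scatter) is expected to stay within the usual scatter of repeated measurements. Compound 3 is therefore estimated at 15000 nM, with a range from 5000 nM to 40000 nM, and a limit rather than a number remains possible.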

Compound 3, half-maximal inhibitory concentration: > 20000 nM
Compound 3: no number, only a limit; the forecaster's own chance of this, stated with the estimate: 30%; middle value at least 1.3-fold (0.12 log units) away from the limit.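

In this assay, compound 3 gives only a limit of the assay, > 20000 nM, not a number. From the compounds shown here alone, at this position, para to a fused ring, 4-fluoro-3-(hydroxymethyl)phenyl in place of 4-methoxyphenyl gives an at least 1.1-fold higher number from compound 2 to compound 3 (0.04 log units; that floor lies within the scatter), so the change brings no measurable gain, and the true size of the step remains unknown. The series now reads mostly as limits: the limit of > 20000 nM in this assay, at which 2 of the 3 values shown sit.

Going by these compounds, whether an amine or a carboxylic acid on the 4-position of this phenyl ring would give a number clearly lower than that of compound 2 stays open.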